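The compounds below may be only part of what the source reports. "The series", "measured", "known", "first", "only" and "open" are said of these compounds alone.

Measured compounds:
- Compound 1, `CC(C)n1nc(S(=O)(=O)c2cccc3ccccc23)c2cc(N3CCN(C)CC3)ccc21`: 1.8 nM
- Compound 2, `Cc1ccc(S(=O)(=O)c2n[nH]c3ccc(N4CCN(C)CC4)cc23)cc1`: 4.9 nM
- Compound 3, `CCCn1nc(S(=O)(=O)c2cccc3ccccc23)c2cc(N3CCNCC3)ccc21`: 2.2 nM

In an assay on HeLa cells for displacement of a labelled ligand from 5-hydroxytryptamine receptor 6 (Homo sapiens) (a higher number here means a weaker inhibitor, a lower number a stronger inhibitor), compound 1 has the lowest of the three numbers. Compound 3 gives a value within the usual scatter of it, so the two cannot be ordered; compound 2 gives a number beyond the scatter, higher than that of compound 1. Compound 4, `CCn1nc(S(=O)(=O)c2cccc3ccccc23)c2cc(N3CCN(C)CC3)ccc21`, has not yet been measured in this assay. It differs from compound 1 by hydrogen in place of methyl on a saturated chain carbon bound to an aromatic nitrogen and a saturated chain carbon. Within the data shown here, no measured pair shows this change, so its size is uncertain; a small step, if any, is expected, because compound 3 with a propyl at that place gives 2.2 nM, close to compound 1. Compound 4 is therefore expected to give about 2.5 nM, between 1 nM and 6 nM, a step of a 1.4-fold higher number from compound 1 to compound 4 (0.14 log units; within the scatter) that is expected to stay within the scatter.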

Compound 4, inhibition constant: 1.7 nM
The estimate for compound 4 lay 1.5-fold (0.17 log units) above the measured number; measured number inside the range.
By their numbers in this assay, from the lowest: compounds 4, 1 and 3 (each within the scatter of the next); then compound 2.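

In this assay, among these compounds, the change from isopropyl to ethyl gives a 1.1-fold lower number from compound 1 to compound 4 (0.02 log units; within the scatter) and is the first single change at this place to be read directly. Hydrogen in place of methyl on this saturated chain carbon therefore produces no step that can be told from scatter, so this one methyl can be removed without a measurable difference in this assay. No measurement shown accounts for this result.

The compounds shown leave open whether the same holds for the other groups that could stand on the aromatic nitrogen, such as a methyl, a longer chain, or a chain ending in an amine or a carboxylic acid. They also leave open how much of this tolerance carries over to the shared core with another sulfonyl aryl group.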